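From chloromethyl to furan-2-yl on a carbonyl carbon

A few compounds are considered here, and "the series" means these few. Any claim that something is new, unique, unknown or untested is made for them only; others in the source may bear on it.

Among the measured compounds shown here, in a functional assay on A-375 cells (Homo sapiens) for cytotoxicity, read by MTT assay (on this read-out lower numbers stand for stronger inhibition and higher numbers for weaker inhibition), compound 3 (`COc1ccc(/C=C/C(=O)c2ccc(OC)c3c2OC(C)(C)C=C3)cc1OC(=O)CCl`) gives 450 nM and stands clear of only one neighbour. Compound 2 (`CCCCC(=O)Oc1cc(/C=C/C(=O)c2ccc(OC)c3c2OC(C)(C)C=C3)ccc1OC`) gives 220 nM, and the step of a 2.0-fold higher number from compound 2 to compound 3 (0.31 log units; beyond the scatter) is modest. Compound 1 (`CCC(=O)Oc1cc(/C=C/C(=O)c2ccc(OC)c3c2OC(C)(C)C=C3)ccc1OC`) gives 240 nM, and the step of a 1.9-fold higher number from compound 1 to compound 3 (0.27 log units; within the scatter) stays within the scatter, as does a 1.1-fold lower number from compound 1 to compound 2 (0.04 log units; within the scatter). Compound 4 (`COc1ccc(/C=C/C(=O)c2ccc(OC)c3c2OC(C)(C)C=C3)cc1OC(=O)c1ccco1`) brings a new change, (furan-2-yl in place of chloromethyl on a carbonyl carbon), with furan-2-yl in place of chloromethyl on a carbonyl carbon. For the measured compounds named here, none of the measured steps introduces a ring, so they bear on it only indirectly, and all three are small. The expected step is accordingly slight, a 1.5-fold lower number from compound 3 to compound 4 (0.18 log units; within the scatter), within the scatter. Compound 4 is estimated at 300 nM, with an expected range of 130 nM to 680 nM.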

Compound 4, half-maximal inhibitory concentration: 680 nM
Compound 4: middle estimate off by 2.3-fold (0.36 log units), on the low side; measured number inside the range.
By their numbers in this assay, from the lowest: compounds 2, 1, 3 and 4 (each within the scatter of the next, the first and the last beyond it).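

In this assay, the first ring on this carbonyl carbon leaves the number close to that of the chloromethyl group: furan-2-yl in place of chloromethyl gives a 1.5-fold higher number from compound 3 to compound 4 (0.18 log units; within the scatter). Against the plain chains the same ring counts for more, with furan-2-yl in place of butyl giving a 3.1-fold higher number from compound 2 to compound 4 (0.49 log units; beyond the scatter) and furan-2-yl in place of ethyl giving a 2.8-fold higher number from compound 1 to compound 4 (0.45 log units; beyond the scatter), both modest. No measurement shown speaks to what lies behind these steps. Still open, as far as these compounds go, is whether a phenyl or thiophen-2-yl ring on this carbonyl carbon would track furan-2-yl, and how an amine on the chain would read.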